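Dropping a Methylsulfanyl Group: Expected Effect on Growth Inhibition

The compounds below may be only part of what the source reports. "The series", "measured", "known", "first", "only" and "open" are said of these compounds alone.

This account concerns two measured compounds and one that has not yet been tested. Compound 1 `CSc1ccc(CNc2nc(SC)nc3ncccc23)cc1` was examined in an ADME assay on 184B5 cells (Homo sapiens) for cytotoxicity, read by MTT assay, with a stated time of 72 h (on this read-out lower numbers stand for stronger inhibition of growth and higher numbers for weaker inhibition of growth), where compound 1 gives 190 nM. Compound 2 `CCCCCSc1nc(NCc2ccc([Se]C)cc2)c2ccccc2n1` was run in the same assay, and in this assay compound 2 gives 73000 nM. Of the two numbers, compound 1 has the lower one, and the gap to compound 2 is well beyond the usual scatter, so compound 1 is the stronger growth inhibitor of the pair.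

Compound 3 `CSc1nc(NCc2ccccc2)c2cccnc2n1` differs from compound 1 in one place: hydrogen in place of methylsulfanyl on an aromatic carbon. Within the data shown here, no measured pair tracks this exact change, so the size of the step cannot be read from the data; the methylsulfanyl group does sit on the ring that carries the rest of the molecule, and its loss is expected to weaken growth inhibition modestly rather than leave it untouched. The step from a 3.2-fold higher number from compound 1 to compound 3 (0.50 log units; beyond the scatter) is therefore expected to be upward. Compound 3 is estimated to give 600 nM in this assay, within a range from 150 nM to 3000 nM.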

Compound 3, concentration for 50% growth inhibition: 49000 nM
Compound 3: middle estimate off by 82-fold (1.91 log units), on the low side; measured number outside the range, above it.
By their numbers in this assay, from the lowest: compound 1; then compounds 3 and 2 (each within the scatter of the next).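

In this assay, taking away the methylsulfanyl group and leaving hydrogen on the aromatic carbon gives a 260-fold higher number from compound 1 to compound 3 (2.41 log units; beyond the scatter). Among these compounds, this is the first pair in the account that differs in one place only, and it shows that this position, para to a large group, is far from indifferent to what it carries: with the rest of the molecule unchanged, the strong growth inhibition of compound 1, at 190 nM, is lost along with this one group. The data show the size of this step but offer no measurement that would explain why the loss counts for so much.

On these data alone, whether this position needs the methylsulfanyl group itself, or whether a methoxy group, a chlorine atom or a longer chain such as ethylsulfanyl would hold the growth inhibition of compound 1, stays open. It is also open whether removing the group would cost as much on a different core, since the one step shown comes from the core of compound 1 alone.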